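Changing the carbonyl substituent of compound 2

This account rests on a few compounds, and the source may have more. Where it says the series, first, only, none or still open, it means among the compounds named here.

Compound 1 `CCC(CC)S(=O)(=O)c1ccc(S(=O)(=O)N2CCC[C@@H](C(=O)N3CCC(F)(F)CC3)C2)cc1` gives 13 nM 
Compound 2 `CCN(CC)S(=O)(=O)c1ccc(S(=O)(=O)N2CCC[C@@H](C(=O)NC3CCOCC3)C2)cc1` gives 3770 nM 

In a functional assay on MIA PaCa-2 cells (Homo sapiens) for inhibition, read by MTT assay, with a stated time of 7 days (on this read-out lower numbers stand for stronger inhibition and higher numbers for weaker inhibition), compound 2 has the higher number of the two, with 3770 nM against the far lower figure of compound 1, a gap beyond the scatter. Compound 3 `CCN(CC)S(=O)(=O)c1ccc(S(=O)(=O)N2CCC[C@@H](C(=O)N3CC[C@@H](OC)C3)C2)cc1` has not yet been measured. Compared with compound 2, it carries 3-methoxypyrrolidin-1-yl in place of (oxan-4-yl)amino on a carbonyl carbon and has the same atoms, joined differently. Among the compounds with values here, no measured step covers this change, so its size is uncertain. Within the data shown here, the only other guide is compound 1 at 13 nM in this assay, and a move towards lower numbers, beyond the scatter, is therefore expected. The estimate amounts to an expected 13-fold lower number from compound 2 to compound 3 (1.10 log units; beyond the scatter) in this read-out. For compound 3 the expected value is 300 nM (estimated range 40 nM to 2500 nM).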

Compound 3, half-maximal inhibitory concentration: 3910 nM
Compound 3: middle estimate off by 13-fold (1.12 log units), on the low side; measured number above the stated range.
By their numbers in this assay, from the lowest: compound 1; then compounds 2 and 3 (each within the scatter of the next).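

In this assay, putting 3-methoxypyrrolidin-1-yl in place of (oxan-4-yl)amino on a carbonyl carbon gives (a 1.0-fold higher number from compound 2 to compound 3 (0.02 log units; within the scatter)), so the two compounds cannot be told apart. At this position, therefore, the six-membered ring can give way to a five-membered ring, the single hydrogen-bond donor of the group can be absent and a defined stereocentre can be added, all without the number leaving the scatter. No measurement is available that explains this result.

Compound 1 differs from both compounds in more than one place, so its far lower number cannot be assigned to the group on the carbonyl carbon alone. On these data alone, whether a piperidin-1-yl or a dimethylamino group at this position, or the opposite configuration of the methoxy-bearing carbon, would separate from compound 2 and compound 3 remains open.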